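A few compounds are considered here, and "the series" means these few. Any claim that something is new, unique, unknown or untested is made for them only; others in the source may bear on it.

In an ADME assay on PBMC cells (Homo sapiens) for cytotoxicity (on this read-out higher numbers stand for lower toxicity in this test and lower numbers for higher toxicity in this test), compound 1 `CC(=O)Nc1nc(N)nc2c1ncn2[C@H]1CO[C@@H](CO)O1` gives > 100000 nM, which is a limit of the assay and not a number. Compound 2 `CCCC(=O)Nc1nc(N)nc2c1ncn2[C@H]1CO[C@@H](CO)O1` gives > 100000 nM, also a limit. Compound 3 `CCCCCCCCCC(=O)Nc1nc(N)nc2c1ncn2[C@H]1CO[C@@H](CO)O1` gives > 100000 nM, again a limit. The three compounds therefore share one result, (the limit of > 100000 nM in this assay, at which 3 of the 3 values shown sit), so the position of compound 1 is known only as a limit.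

Compound 4 `CCCCCCCCCCCC(=O)Nc1nc(N)nc2c1ncn2[C@H]1CO[C@@H](CO)O1` has not yet been measured. Its difference from compound 1 is decyl in place of hydrogen on a saturated chain carbon bound to a carbonyl carbon, which is decyl in place of hydrogen on a saturated chain carbon bound to a carbonyl carbon.

The closest evidence is a step that the two limits leave unreadable from compound 1 to compound 3, where octyl enters at the same place. The shorter change, a step that the two limits leave unreadable from compound 1 to compound 2, and the further extension, a step that the two limits leave unreadable from compound 2 to compound 3, bear on it too. None of these steps has a readable size, and none shows a direction, so no step beyond the usual scatter is expected in this assay.

The expected change is a number no higher from compound 1 to compound 4 (the limit leaves the size open). For compound 4, the estimated value is 100000 nM, with an expected range from 40000 nM to 100000 nM.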

Compound 4, half-maximal cytotoxic concentration: 60000 nM
Beside the measured number, compound 4's estimate is 1.7-fold (0.22 log units) above it; low and high end bracket the measured number.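

Among the compounds shown here, with decyl in place of hydrogen on a saturated chain carbon bound to a carbonyl carbon, compound 4 gives the first true number at this position in this assay, not a limit. Set against the compounds with shorter chains, the result reads as an at least 1.6-fold lower number from compound 1 to compound 4 (0.22 log units; that floor lies within the scatter), as an at least 1.6-fold lower number from compound 2 to compound 4 (0.22 log units; that floor lies within the scatter) and as an at least 1.6-fold lower number from compound 3 to compound 4 (0.22 log units; that floor lies within the scatter). Each of these steps is only a floor, since the values of the other three compounds are limits: the limit of > 100000 nM in this assay, at which 3 of the 4 values shown sit.

From the compounds shown here alone, whether the real gap reaches beyond the usual scatter stays open, and the steps among compound 1, compound 2 and compound 3 cannot be read at all. Also open, going by these compounds, is what a longer chain, or a chain ending in an amine or a carboxylic acid, would give at this place.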